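A few compounds are considered here, and "the series" means these few. Any claim that something is new, unique, unknown or untested is made for them only; others in the source may bear on it.

For the measured compounds named here, compound 3 `O=C(O)Cc1sc(C(c2ccc(F)cc2)c2ccc(F)cc2)nc1-c1cccc(F)c1` is one of three compounds measured in an in vitro functional assay on HEK285-7 cells for antagonist activity at prostaglandin D2 receptor 2 (Homo sapiens), read by BRET and beta-arrestin recruitment; on this read-out lower numbers stand for smaller maximal responses and higher numbers for larger maximal responses. In this assay compound 3 gives 80%. Compound 2 `O=C(O)Cc1sc(C(c2ccc(F)cc2)c2ccc(F)cc2)nc1-c1ccncc1` gives 80% in this assay, and no change at the digits printed from compound 2 to compound 3 (within the scatter). Compound 1 `COc1cc(-c2nc(C(c3ccc(F)cc3)c3ccc(F)cc3)sc2CC(=O)O)ccn1` gives 60% in this assay, and a number 20 percentage points higher from compound 1 to compound 3 (beyond the scatter), much as a number 20 percentage points higher from compound 1 to compound 2 (beyond the scatter). Compound 3 therefore stands level with compound 2 and, together with it, at the top of the three numbers, with compound 1 the furthest away.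

Compound 4 `N#Cc1ccc(-c2nc(C(c3ccc(F)cc3)c3ccc(F)cc3)sc2CC(=O)O)cc1` has not yet been measured in this assay. The change from compound 3 is 4-cyanophenyl in place of 3-fluorophenyl on an aromatic carbon. The three measured compounds differ from one another only at that place on the shared core. Going by the values given here, two measured steps bear on the new change: the swap of one six-membered aromatic ring for another between compound 2 and compound 3 stayed within the scatter, while the swap between compound 1 and compound 3 went beyond it. Among the compounds with values here, no measured compound carries a 4-cyanophenyl, so there is no direct precedent. For compound 4 only a small step, within the scatter, is expected, a number 5 percentage points lower from compound 3 to compound 4 (within the scatter). Compound 4 is therefore estimated at 75%, with a range of 55% to 95%.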

Compound 4, largest response reached (reported as efficacy), in percent of the reference or control that the assay uses: 30%
The estimate for compound 4 lay 45 percentage points above the measured number; measured number outside the range, below it.
By their numbers in this assay, from the lowest: compound 4; then compound 1; then compounds 2 and 3 (each within the scatter of the next).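

In this assay this position proves far from indifferent to the aromatic ring it carries, even though no change at the digits printed from compound 2 to compound 3 (within the scatter) had suggested that one ring could stand in for another: 4-cyanophenyl brings a number 50 percentage points lower from compound 3 to compound 4 (beyond the scatter) and also a number 50 percentage points lower from compound 2 to compound 4 (beyond the scatter) in place of the two rings that gave the highest numbers. The new ring also falls short of the 2-methoxypyridin-4-yl ring, the lowest of the earlier three, with a number 30 percentage points lower from compound 1 to compound 4 (beyond the scatter) on the same core, so compound 4 has the lowest number of the four and the range seen at this position is much wider than it first appeared. No supporting data are available to account for this large step.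

The change from compound 3 to compound 4 replaces the fluorine with a nitrile and also alters where the substituent sits on the phenyl ring, so these four compounds cannot show which of the two matters more. As far as these compounds go, how an unsubstituted phenyl, or a phenyl carrying an amine or a carboxylic acid, would behave at this position remains open.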